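Swapping the Aryl Group in a Quinoline Urea Series

The source may hold more compounds than are shown below. What is called first, only, known or untested is meant among the compounds shown, and "the series" means these compounds.

Of the compounds shown here, three have been measured in a functional assay on CCRF-CEM cells (Homo sapiens) for inhibition, read by MTT assay, with a stated time of 72 h; on this read-out higher numbers stand for weaker inhibition and lower numbers for stronger inhibition. Compound 1 `COc1cc(NC(C)CCCNC(=O)Nc2ccc(F)cc2)c2ncccc2c1` gives 26000 nM, compound 2 `COc1cc(NC(C)CCCNC(=O)Nc2ccc(C(F)(F)F)cc2)c2ncccc2c1` gives 14000 nM, and compound 3 `COc1cc(NC(C)CCCNC(=O)NNC(=O)Nc2cccc(C(F)(F)F)c2)c2ncccc2c1` gives 6900 nM. Compound 3 therefore shows the lowest number of the three, and since its distance to compound 2 and to compound 1 both lie beyond the scatter, it is the strongest inhibitor seen so far.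

Compound 4 `COc1cc(NC(C)CCCNC(=O)NNC(=O)Nc2ccc(F)cc2)c2ncccc2c1` differs from compound 3 in one place: 4-fluorophenyl in place of 3-(trifluoromethyl)phenyl on an amide-type nitrogen. Within the data shown here, the only measured step that touches a similar change is a 1.9-fold lower number from compound 1 to compound 2 (0.27 log units; within the scatter), which went in the opposite direction, from fluoro to trifluoromethyl, and stayed within the scatter. Read backwards, it suggests the number for compound 4 may rise a little, though the change here also moves the group from the 3-position to the 4-position, for which no step has been measured. The expectation is a small shift, a 1.9-fold higher number from compound 3 to compound 4 (0.28 log units; within the scatter), toward weaker inhibition. Compound 4 is estimated at 13000 nM, with a range from 5000 nM to 35000 nM.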

Compound 4, half-maximal inhibitory concentration: 118000 nM
For compound 4 the middle estimate is 9.1-fold (0.96 log units) below the measured one; measured number above the stated range.
By their numbers in this assay, from the lowest: compound 3; then compounds 2 and 1 (each within the scatter of the next); then compound 4.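

Putting 4-fluorophenyl in place of 3-(trifluoromethyl)phenyl on this amide-type nitrogen gives a 17-fold higher number from compound 3 to compound 4 (1.23 log units; beyond the scatter) in this assay, so the aryl group at this place can matter far more than the small step of a 1.9-fold lower number from compound 1 to compound 2 (0.27 log units; within the scatter) had hinted. The longer chain therefore does not bring stronger inhibition by itself: ((4-fluorophenyl)carbamoyl)amino in place of 4-fluorophenyl gives a 4.5-fold higher number from compound 1 to compound 4 (0.66 log units; beyond the scatter) and in place of 4-(trifluoromethyl)phenyl gives an 8.4-fold higher number from compound 2 to compound 4 (0.93 log units; beyond the scatter) as a weaker result, while compound 3, with the same longer chain, has the lowest number. No measurement shown here bears on why these numbers differ.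

Going by these compounds, the identity of the substituent and its ring position change together in this step, so their separate contributions remain open. Also open, on these data alone, is how a nitrile or an amine on this aryl ring would read.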